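Step from compound 2 within a series at its limits

The compounds below may be only part of what the source reports. "The series", "measured", "known", "first", "only" and "open" are said of these compounds alone.

- compound 1 `O=C(Nc1cccc(-n2cc(-c3ccncc3)c(-c3ccc(Cl)c(O)c3)n2)c1)Nc1cccc(C(F)(F)F)c1`: > 32500 nM
- compound 2 `COc1cc(-c2nn(-c3cccc(NC(=O)c4cccc(C(F)(F)F)c4)c3)cc2-c2ccncc2)ccc1Cl`: > 50000 nM
- compound 3 `COc1cc(-c2nn(-c3cccc(NC(=O)Nc4ccc(Cl)c(Cl)c4)c3)cc2-c2ccncc2)ccc1Cl`: > 50000 nM

All three entries are limits, not numbers. In a functional assay on HCT-116 cells (Homo sapiens) for inhibition, read by sulforhodamine B assay, with a stated time of 48 h (a lower number here means that less compound is tolerated, a higher number that more compound is tolerated), compound 2 stands only at the limit > 50000 nM. Compound 4 `COc1cc(-c2nn(-c3cccc(NC(=O)Nc4ccc(Cl)c(C(F)(F)F)c4)c3)cc2-c2ccncc2)ccc1Cl` is not yet measured and differs from compound 2 as follows: (4-chloro-3-(trifluoromethyl)phenyl)amino in place of 3-(trifluoromethyl)phenyl on a carbonyl carbon. The closest measured change is a step that the two limits leave unreadable from compound 2 to compound 3, and its size cannot be read. Compound 3 also stands only at the limit > 50000 nM. The series gives no measured number, and the limit of > 50000 nM in this assay, at which 2 of the 3 values shown sit, is the commonest result, so no step beyond the scatter is expected in this assay, in either direction. The expected change is a number no higher from compound 2 to compound 4 (the limit leaves the size open). For compound 4 the estimate is 50000 nM, with an expected range of 20000 nM to 100000 nM.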

Compound 4, concentration lethal to 50% of the cells: 21500 nM
Estimate against measurement, compound 4: 2.3-fold (0.37 log units) above, and the stated range covers the measured number.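

In this assay, the group on the carbonyl carbon now produces a readable shift: (4-chloro-3-(trifluoromethyl)phenyl)amino in place of 3-(trifluoromethyl)phenyl gives an at least 2.3-fold lower number from compound 2 to compound 4 (0.36 log units; beyond the scatter). On an aromatic carbon of that group, trifluoromethyl in place of chloro gives an at least 2.3-fold lower number from compound 3 to compound 4 (0.36 log units; beyond the scatter), so this single change is enough to bring the series off its limit. The step between compound 2 and compound 3 joins two limits and cannot be read.

From the compounds shown here alone, with only compound 4 giving a number, the full size of both readable steps stays open. Also open, going by these compounds, is how an amine or a carboxylic acid in place of that trifluoromethyl would read.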